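This account rests on a few compounds, and the source may have more. Where it says the series, first, only, none or still open, it means among the compounds named here.

Measured so far in a physicochemical assay for solubility; on this read-out lower numbers stand for lower solubility and higher numbers for higher solubility:

- Compound 1 `O=C(NC[C@H](NS(=O)(=O)c1ccccc1)C(=O)O)c1ccc(N2CCC(NC3=NCCCN3)CC2)cc1`: < 100 ug/mL, which is a limit of the assay and not a number
- Compound 2 `O=C(NC[C@H](NS(=O)(=O)c1ccccc1)C(=O)O)c1ccc(N2CCC(NC3=NCCCN3)CC2)c(F)c1`: 600 ug/mL

For the measured compounds named here, compound 2, at 600 ug/mL, holds the only true number in this small set, so it has no exact value to be ranked against. The next structure, compound 3 `COc1cc(C(=O)NC[C@H](NS(=O)(=O)c2ccccc2)C(=O)O)ccc1N1CCC(NC2=NCCCN2)CC1`, differs from compound 2 in one place: methoxy in place of fluoro on an aromatic carbon. In words, this is methoxy in place of fluoro on an aromatic carbon.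

Going by the values given here, only one measured step bears on this change: an at least 6.0-fold higher number from compound 1 to compound 2 (0.77 log units; beyond the scatter), where fluoro took the place of hydrogen on an aromatic carbon. Among the compounds with values here, that step was beyond the scatter, but no measured compound carries methoxy, so the comparison is indirect. Like compound 2, compound 3 has a group other than hydrogen on that ring, so the expectation is that it stays closer to compound 2 than to the limit seen for compound 1. A slightly lower number is expected, with no step beyond the scatter in this assay. The expected step is a 1.5-fold lower number from compound 2 to compound 3 (0.18 log units; within the scatter). For compound 3 the estimated value is 400 ug/mL, with an expected range of 120 ug/mL to 1200 ug/mL.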

Compound 3, solubility: 1300 ug/mL
For compound 3 the middle estimate is 3.3-fold (0.51 log units) below the measured one; measured number outside the range, above it.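

In this assay, this position, ortho to a large group and meta to a large group, can now be judged with two groups other than hydrogen. The change from fluoro to methoxy gives a 2.2-fold higher number from compound 2 to compound 3 (0.34 log units; beyond the scatter), so the identity of the group matters here, not only whether a hydrogen has been replaced. Set against hydrogen, methoxy gives an at least 13-fold higher number from compound 1 to compound 3 (1.11 log units; beyond the scatter), and the true size of this step cannot be read, as compound 1 stands at a limit of the assay and not at a number: the limit of < 100 ug/mL in this assay, at which 1 of the 3 values shown sits.

One pair cannot separate the possible differences between fluoro and methoxy, as methoxy brings both one more heavy atom and a hydrogen-bond acceptor that fluoro lacks. An ethoxy group, a hydroxyl or an amine at this same position could help tell these apart, and the compounds shown also leave open whether methoxy gives a similar step elsewhere on the ring.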